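From 3-Methoxyphenyl to 3,4,5-Trimethoxyphenyl in a Two-Compound Series

The source may report more compounds than this note shows. Statements on the series, on what has been measured and on what is new or still open speak of the compounds shown alone.

In a functional assay on THP-1 cells (Homo sapiens) for cytotoxicity, read by sulforhodamine B assay, with a stated time of 48 h (on this read-out lower numbers stand for stronger inhibition and higher numbers for weaker inhibition), compound 1 (`COc1cc(/C=C/C(=O)/C=C/c2cccc3ccccc23)ccc1OCc1cn(CCOc2cc(=O)oc3ccccc23)nn1`) gives 4480 nM, and compound 2 (`COc1cccc(/C=C/C(=O)/C=C/c2ccc(OCc3cn(CCOc4cc(=O)oc5ccccc45)nn3)c(OC)c2)c1`) gives 7130 nM. These two values lie within the scatter of each other, so compound 2 stands level with compound 1 on the numbers available. Compound 3 (`COc1cc(/C=C/C(=O)/C=C/c2cc(OC)c(OC)c(OC)c2)ccc1OCc1cn(CCOc2cc(=O)oc3ccccc23)nn1`) has not yet been measured. It carries 3,4,5-trimethoxyphenyl in place of the 3-methoxyphenyl of compound 2 on a double-bonded chain carbon bound to a double-bonded chain carbon: 3,4,5-trimethoxyphenyl in place of 3-methoxyphenyl on a double-bonded chain carbon bound to a double-bonded chain carbon. For the measured compounds named here, only one measured step bears on this place, a 1.6-fold higher number from compound 1 to compound 2 (0.20 log units; within the scatter), with 3-methoxyphenyl in place of naphthalen-1-yl. That step stayed within the scatter, but it is a single pair involving a different group. No step beyond the scatter is therefore expected in this assay, in either direction. The expected step is a 1.2-fold lower number from compound 2 to compound 3 (0.07 log units; within the scatter). The estimate for compound 3 is 6000 nM, with an expected range from 2500 nM to 14000 nM.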

Compound 3, half-maximal inhibitory concentration: 820 nM
Estimate against measurement, compound 3: 7.3-fold (0.86 log units) above; the whole stated range lies above it.
By their numbers in this assay, from the lowest: compound 3; then compounds 1 and 2 (each within the scatter of the next).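

In this assay, the position on a double-bonded chain carbon bound to a double-bonded chain carbon turned out to be able to move the number well beyond the scatter, which the earlier pair had not shown: 3,4,5-trimethoxyphenyl in place of 3-methoxyphenyl gives an 8.7-fold lower number from compound 2 to compound 3 (0.94 log units; beyond the scatter), while the same group in place of naphthalen-1-yl gives a 5.5-fold lower number from compound 1 to compound 3 (0.74 log units; beyond the scatter). Compound 3 therefore stands as the most potent of the three, and 3,4,5-trimethoxyphenyl is the only group shown here that separates from the others at this position. Nothing measured here accounts for the drop.

The compounds shown leave open whether a phenyl ring carrying a dimethylamino group, a hydroxyl or a carboxylic acid would give a similar number. They also leave open how a ring with two methoxy groups would compare with compound 3.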